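Swapping the Substituted Ring in an Acrylic Acid Series

The compounds below may be only part of what the source reports. "The series", "measured", "known", "first", "only" and "open" are said of these compounds alone.

Three compounds share a common core and were tested in a functional assay on MCF7 cells (Homo sapiens) for inhibition; on this read-out lower numbers stand for stronger inhibition and higher numbers for weaker inhibition. Compound 1 `CC/C(=C(/c1ccc(/C=C/C(=O)O)cc1)c1cc2ccccc2[nH]1)c1ccccc1` gives 108 nM. Compound 2 `CC/C(=C(/c1ccc(/C=C/C(=O)O)cc1)c1cc2ccccc2[nH]1)c1ccccc1C` gives 33 nM, and compound 3 `CC/C(=C(/c1ccc(/C=C/C(=O)O)cc1)c1cc2ccccc2[nH]1)c1ccccc1Cl` gives 42 nM. Among these three numbers compound 3 stands second highest: its nearest neighbour is compound 2, within the scatter, while compound 1 lies further away, beyond it. The two steps from compound 1 show a 3.3-fold lower number from compound 1 to compound 2 (0.51 log units; beyond the scatter) and a 2.6-fold lower number from compound 1 to compound 3 (0.41 log units; beyond the scatter), so placing a small group on that ring gave a modest gain each time; the direct comparison a 1.3-fold higher number from compound 2 to compound 3 (0.10 log units; within the scatter) stays within the scatter.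

Compound 4 `CC/C(=C(/c1ccc(/C=C/C(=O)O)cc1)c1cc2ccccc2[nH]1)c1cccc(OC(F)(F)F)c1` is not yet measured. It differs from compound 3 by 3-(trifluoromethoxy)phenyl in place of 2-chlorophenyl on a double-bonded chain carbon bound to a double-bonded chain carbon and a saturated chain carbon. Among the compounds with values here, no measured step tests a group at that position on the ring or a trifluoromethoxy group, so the measured steps only show that a substituent on this ring has so far helped modestly. The expectation for compound 4 is therefore a number near that of compound 3, with a 1.4-fold higher number from compound 3 to compound 4 (0.15 log units; within the scatter) and an estimate of 60 nM, between 20 nM and 200 nM.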

Compound 4, half-maximal inhibitory concentration: 282 nM
Compound 4: middle estimate off by 4.7-fold (0.67 log units), on the low side; the whole stated range lies below it.
By their numbers in this assay, from the lowest: compounds 2 and 3 (each within the scatter of the next); then compound 1; then compound 4.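

Adding a trifluoromethoxy group to this ring gives a 2.6-fold higher number from compound 1 to compound 4 (0.42 log units; beyond the scatter) in this assay, so a substituent here does not always lower the number, as methyl and chloro did. Against the two better compounds the gap is wider, with a 6.7-fold higher number from compound 3 to compound 4 (0.83 log units; beyond the scatter) and an 8.5-fold higher number from compound 2 to compound 4 (0.93 log units; beyond the scatter) as the steps, which shows that the choice of aryl group on this double-bonded chain carbon can move the number in either direction. Nothing measured here bears on why this change raises the number.

The compounds shown leave open whether the higher number follows the trifluoromethoxy group itself or its place on the ring, as both change together in these steps. A 3-chlorophenyl or 3-methylphenyl group on this carbon would help separate the two.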